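Swapping methoxy for bromo in a small series

The compounds below may be only part of what the source reports. "The series", "measured", "known", "first", "only" and "open" are said of these compounds alone.

Measured so far:
compound 1 `CCc1ccccc1OS(=O)(=O)c1ccc(N2CCN(C)C2=O)cc1`: 4600 nM
compound 2 `Cc1ccc(OS(=O)(=O)c2ccc(N3CCN(C)C3=O)cc2)c(C)c1`: 3000 nM
compound 3 `COc1cccc(OS(=O)(=O)c2ccc(N3CCN(C)C3=O)cc2)c1`: 2500 nM

These values come from a functional assay on HT-29 cells (Homo sapiens) for antiproliferative activity, read by sulforhodamine B assay, with a stated time of 48 h; a higher number here means a weaker inhibitor, a lower number a stronger inhibitor. Compound 3, at 2500 nM, cannot be separated from the other two compounds, as the data show a 1.2-fold lower number from compound 2 to compound 3 (0.08 log units; within the scatter) and a 1.8-fold lower number from compound 1 to compound 3 (0.26 log units; within the scatter).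

Compound 4 `CN1CCN(c2ccc(S(=O)(=O)Oc3cccc(Br)c3)cc2)C1=O` keeps the rest of compound 3 but has bromo in place of methoxy on an aromatic carbon, meta to a large group: bromo in place of methoxy on an aromatic carbon.

Going by the values given here, no measured step makes this exact swap, so the evidence is indirect. The nearest guide is how far this assay has moved when one substituted phenyl replaces another. The data show a 1.5-fold lower number from compound 1 to compound 2 (0.19 log units; within the scatter) and a 1.8-fold lower number from compound 1 to compound 3 (0.26 log units; within the scatter), alongside the two-compound comparison already given for compound 3. None of these changes exceeds the usual scatter, so no step beyond the scatter is expected here, and the data favour no direction. Three compounds are a thin basis, however, and none of them carries bromo, so the range is kept wide.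

The expected step is no change at the digits printed from compound 3 to compound 4 (within the scatter).

For compound 4 the estimated value is 2500 nM, with an expected range of 900 nM to 7000 nM.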

Compound 4, half-maximal inhibitory concentration: 1300 nM
Estimate against measurement, compound 4: 1.9-fold (0.28 log units) above; measured number inside the range.
By their numbers in this assay, from the lowest: compounds 4, 3, 2 and 1 (each within the scatter of the next, the first and the last beyond it).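

In this assay, the swap at this place on the ring cannot be told apart from no change, since bromo in place of methoxy gives a 1.9-fold lower number from compound 3 to compound 4 (0.28 log units; within the scatter) and the scatter covers that step. Even so, compound 4 is the first compound here to separate from others in the set. Going by these compounds alone, the comparisons with the other aryl groups on the oxygen give a 2.3-fold lower number from compound 2 to compound 4 (0.36 log units; beyond the scatter) and a 3.5-fold lower number from compound 1 to compound 4 (0.55 log units; beyond the scatter), both modest, while no step among compound 1, compound 2 and compound 3 left the scatter. Nothing at hand measures a property of these groups that could explain the two modest steps, so they stand as observations without a cause.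

With methoxy and bromo as the only two groups shown on this aromatic carbon, it remains open how a fluoro, a nitrile, an amine or a carboxylic acid in the same place would read. From the compounds shown here alone, it also remains open whether adding bromo to the 2-ethylphenyl group of compound 1 or the 2,4-dimethylphenyl group of compound 2 would lower the number in the same assay, this assay.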